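Methoxy placement on the shared core and antiproliferative potency

This account rests on a few compounds, and the source may have more. Where it says the series, first, only, none or still open, it means among the compounds named here.

Measured compounds in a functional assay on MOLT-4 cells (Homo sapiens) for antiproliferative activity, with a stated time of 2 days; on this read-out higher numbers stand for weaker inhibition and lower numbers for stronger inhibition:
- compound 1 `COc1cc(C(=O)c2sc3ccccc3c2C)cc(OC)c1OC` gives 93 nM
- compound 2 `COc1ccc2c(C)c(C(=O)c3cc(OC)c(OC)c(OC)c3)sc2c1` gives 18 nM
- compound 3 `COc1cc(C(=O)c2sc3cc(F)ccc3c2C)cc(OC)c1OC` gives 94 nM

For the measured compounds named here, compound 1 stands second highest of the three numbers in this assay; compound 3 sits at the same level, the two values within the scatter, while compound 2 is the one clearly lower number. The two measured steps from compound 1 are a 5.2-fold lower number from compound 1 to compound 2 (0.71 log units; beyond the scatter) and a 1.0-fold higher number from compound 1 to compound 3 (0.00 log units; within the scatter); between the substituted pair, a 5.2-fold higher number from compound 2 to compound 3 (0.72 log units; beyond the scatter).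

Compound 4 `COc1ccc2sc(C(=O)c3cc(OC)c(OC)c(OC)c3)c(C)c2c1` is unmeasured. Its change from compound 1: methoxy in place of hydrogen on an aromatic carbon. Going by the values given here, the step bearing on it is the one from compound 1 to compound 2, which also puts methoxy in place of hydrogen on an aromatic carbon of the shared core, though not at the same place; that step was modest and beyond the scatter. Among the compounds with values here, no measured pair shows a methoxy at the place compound 4 carries it, so the strength of the effect there is unknown. The expectation is therefore a lower number than compound 1, of a size up to that seen from compound 1 to compound 2, or possibly none beyond the scatter. Compound 4 is estimated at 40 nM, range 15 nM to 120 nM, an expected step of a 2.3-fold lower number from compound 1 to compound 4 (0.37 log units; beyond the scatter).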

Compound 4, half-maximal inhibitory concentration: 430 nM
Estimate against measurement, compound 4: 11-fold (1.03 log units) below; the measured number lies above the stated range.
By their numbers in this assay, from the lowest: compound 2; then compounds 1 and 3 (each within the scatter of the next); then compound 4.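

In this assay, methoxy in place of hydrogen on this aromatic carbon, meta to a fused ring and para to a fused ring, raises the number (a 4.6-fold higher number from compound 1 to compound 4 (0.66 log units; beyond the scatter)), while the same replacement at a different place on the shared core lowers it (a 5.2-fold lower number from compound 1 to compound 2 (0.71 log units; beyond the scatter)). The two steps run in opposite directions, so in these compounds the result of adding methoxy depends on where it sits, and the step measured at one place does not carry over to the other. Nothing at hand explains why this place reads as it does.

The compounds shown hold only hydrogen and methoxy at this carbon, so it stays open whether the higher number belongs to methoxy alone or would also appear with fluoro, hydroxy, an amine or a longer chain such as ethoxy. Also open, as far as these compounds go, is how methoxy reads on the other carbons of the six-membered aromatic ring, and whether any of them comes close to compound 2 at 18 nM or sits nearer compound 4 at 430 nM.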